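Phenoxy replaced by a sulfonylamino group in compound 1

The source may report more compounds than this note shows. Statements on the series, on what has been measured and on what is new or still open speak of the compounds shown alone.

In a functional assay on HepG2 cells (Homo sapiens) for antiproliferative activity, read by MTT assay, with a stated time of 48 h (on this read-out lower numbers stand for stronger inhibition and higher numbers for weaker inhibition), compound 1 `COc1ccc(CN(C(=O)Cn2cc(COc3ccccc3)nn2)c2cc(OC)c(OC)c(OC)c2)cc1` gives 20500 nM. Compound 2 `COc1ccc(CN(C(=O)Cn2cc(CSc3nnc(-c4ccccc4)c(-c4ccccc4)n3)nn2)c2cc(OC)c(OC)c(OC)c2)cc1` gives 21800 nM, and compound 3 `COc1ccc(CN(C(=O)Cn2cc(CSc3nnnn3C)nn2)c2cc(OC)c(OC)c(OC)c2)cc1` gives 28300 nM. Compound 1 therefore stands within the scatter of both other compounds, and these numbers do not separate it from either.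

The change under consideration leads to compound 4 `COc1ccc(CN(C(=O)Cn2cc(CNS(=O)(=O)c3ccc(C)cc3)nn2)c2cc(OC)c(OC)c(OC)c2)cc1`: ((4-methylphenyl)sulfonyl)amino in place of phenoxy on a saturated chain carbon bound to an aromatic carbon. In words, ((4-methylphenyl)sulfonyl)amino comes in place of phenoxy on a saturated chain carbon bound to an aromatic carbon. For the measured compounds named here, the one measured step bearing on this is a 1.4-fold higher number from compound 1 to compound 3 (0.14 log units; within the scatter), with (1-methyl-1H-tetrazol-5-yl)sulfanyl in place of phenoxy, and it stays within the scatter. Going by the values given here, no measured compound carries the entering group, so this step offers only indirect guidance and the range is kept wide.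

No shift beyond the scatter is expected in this assay, and the estimated step is a 1.1-fold higher number from compound 1 to compound 4 (0.03 log units; within the scatter). For compound 4 the expected value is 22000 nM, with an estimated range of 10000 nM to 45000 nM.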

Compound 4, half-maximal inhibitory concentration: 30500 nM
For compound 4 the middle estimate is 1.4-fold (0.14 log units) below the measured one, and the stated range covers the measured number.
By their numbers in this assay, from the lowest: compounds 1, 2, 3 and 4 (each within the scatter of the next).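

Exchanging phenoxy for ((4-methylphenyl)sulfonyl)amino gives a 1.5-fold higher number from compound 1 to compound 4 (0.17 log units; within the scatter) in this assay, so on this saturated chain carbon bound to an aromatic carbon a group with 11 heavy atoms and 1 hydrogen-bond donor is not separated from one with 7 heavy atoms and 0 hydrogen-bond donors. Against (1-methyl-1H-tetrazol-5-yl)sulfanyl, the same entering group gives a 1.1-fold higher number from compound 3 to compound 4 (0.03 log units; within the scatter), so the nitrogen-linked sulfonyl group is likewise not separated from this sulfur-linked group. No supporting measurement is available to explain this lack of separation.

Going by these compounds, it remains open whether any replacement at this place can produce a step beyond the scatter in this assay. A primary amine or a carboxylic acid in place of phenoxy would test this with groups unlike those shown.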